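The source may hold more compounds than are shown below. What is called first, only, known or untested is meant among the compounds shown, and "the series" means these compounds.

Compound 1 `COc1ccc(N(C)c2ccnc(Cl)n2)cc1OCCCCC[Se]C#N`: > 10000 nM (a limit)
Compound 2 `COc1ccc(N(C)c2cc(C)nc(C)n2)cc1`: 277 nM

Both compounds were tested in a functional assay on A549 cells (Homo sapiens) for antiproliferative activity, read by MTT assay, with a stated time of 48 h; a higher number here means a weaker inhibitor, a lower number a stronger inhibitor. Compound 1 gave only a limit. Among the measured compounds shown here, compound 2 therefore holds the only actual number, 277 nM, so its standing cannot be judged against a second number. Compound 3 `COc1ccc(N(C)c2cc(C)nc(C)n2)cc1O` differs from compound 2 by one change, hydroxy in place of hydrogen on an aromatic carbon: a hydroxy in place of hydrogen on an aromatic carbon, ortho to a methoxy group. For the measured compounds named here, no measured pair shows what this change does, so no shift beyond the scatter is expected in either direction. The expected step of a 1.1-fold lower number from compound 2 to compound 3 (0.04 log units; within the scatter) is therefore small. Compound 3 is estimated at 250 nM, with an expected range of 70 nM to 900 nM.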

Compound 3, half-maximal inhibitory concentration: 113 nM
Estimate against measurement, compound 3: 2.2-fold (0.34 log units) above; low and high end bracket the measured number.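

In this assay, hydroxy in place of hydrogen on the aromatic carbon ortho to a methoxy group gives a 2.5-fold lower number from compound 2 to compound 3 (0.39 log units; beyond the scatter), a modest gain that lies beyond the scatter. Among the compounds shown here, this is the first step read at this position, since the earlier compounds offered no such pair, and it shows that the position accepts this change without loss. Nothing shown here accounts for the size of the step. As far as these compounds go, it remains open whether an amine or a carboxylic acid at the same position would move the number further, or in the opposite direction.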